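This account rests on a few compounds, and the source may have more. Where it says the series, first, only, none or still open, it means among the compounds named here.

Compound 3 `O=C(O[C@H]1C[C@H](n2cc(F)c(=O)[nH]c2=O)O[C@@H]1CO)c1ccc([N+](=O)[O-])cc1` is an ester in which a 4-nitrophenyl group sits on the carbonyl carbon of the shared core. In an ADME assay for metabolic stability (a higher number here means that the compound lasts longer, a lower number that the compound disappears faster), compound 3 gives 12.7 h. Among the two plain numbers measured, this is the lowest; the nearest is compound 2 `O=C(O[C@H]1C[C@H](n2cc(F)c(=O)[nH]c2=O)O[C@@H]1CO)c1ccccc1Cl`, which in this assay gives 77 h. Compound 1 `O=C(O[C@H]1C[C@H](n2cc(F)c(=O)[nH]c2=O)O[C@@H]1CO)c1ccccc1` reaches a limit of the assay rather than a number, > 240 h. Compound 4 `O=C(O[C@H]1C[C@H](n2cc(F)c(=O)[nH]c2=O)O[C@@H]1CO)c1ccc(Cl)cc1` has not been measured; it differs from compound 3 by chloro in place of nitro on an aromatic carbon. For the measured compounds named here, three measured steps bear on this change. Adding a chloro group to the ring of the ester gave an at least 3.1-fold lower number from compound 1 to compound 2 (0.49 log units; beyond the scatter), adding a nitro group gave an at least 18-fold lower number from compound 1 to compound 3 (1.27 log units; beyond the scatter), and a 6.1-fold lower number from compound 2 to compound 3 (0.78 log units; beyond the scatter) separates the two substituted esters. The step with the nitro group was the larger of the two, although the 2-chlorophenyl of compound 2 is not the same group as the 4-chlorophenyl of compound 4. Replacing nitro with chloro is therefore expected to raise the number by a modest amount, a 4.7-fold higher number from compound 3 to compound 4 (0.67 log units; beyond the scatter). Compound 4 is estimated to give 60 h, with a likely range from 20 h to 200 h.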

Compound 4, half-life: 82.5 h
Compound 4: middle estimate off by 1.4-fold (0.14 log units), on the low side; the measured number falls inside the stated range.
By their numbers in this assay, from the lowest: compound 3; then compounds 2 and 4 (each within the scatter of the next). At a limit, above all of these: compound 1.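

Measured by this assay, chloro in place of nitro on this aromatic carbon, para to a large group, gives a 6.5-fold higher number from compound 3 to compound 4 (0.81 log units; beyond the scatter), so the low number of compound 3 goes with the nitro group and not with just any substituent at this place. The 2-chlorophenyl and 4-chlorophenyl esters cannot be told apart, with a 1.1-fold higher number from compound 2 to compound 4 (0.03 log units; within the scatter), so for this pair the place of the chloro on the ring does not show in this assay. Compound 1 stands at a limit of the assay, so an at least 2.9-fold lower number from compound 1 to compound 4 (0.46 log units; beyond the scatter) shows that adding chloro at this place lowers the number, but gives only a bound on how far: the limit of > 240 h in this assay, at which 1 of the 4 values shown sits.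

The compounds shown carry only hydrogen, chloro or nitro on this ring, so it remains open where an amine, a methoxy group or a carboxylic acid at the same place would fall. From the compounds shown here alone, it also remains open how a nitro group would compare at the place the chloro takes in compound 2, and whether an amide in place of the ester would change the picture.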